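A few compounds are considered here, and "the series" means these few. Any claim that something is new, unique, unknown or untested is made for them only; others in the source may bear on it.

Measured compounds:
- compound 1, `CCOc1ccc(-c2cnc(NC(=O)CCCCCCNC(=O)C(O)(O)C(F)(F)F)s2)cc1` — in a functional assay on HCT-116 cells (Homo sapiens) for inhibition, read by colorimetric assay, with a stated time of 3 days (on this read-out lower numbers stand for stronger inhibition and higher numbers for weaker inhibition), compound 1 gives 4050 nM
- compound 2, `COc1ccccc1NC(=O)CCCCCCNC(=O)C(O)(O)C(F)(F)F` — in this assay compound 2 gives 10100 nM

Compound 2 carries the higher of the two numbers recorded so far; its nearest neighbour, compound 1, sits at a lower number, and the gap between the two lies beyond the usual scatter. The two share the linker and the terminal trifluoromethyl-bearing group and differ in the aryl amide portion, so the two values alone give no isolated single-point comparison.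

Compound 3, `COc1cccc(NC(=O)CCCCCCNC(=O)C(O)(O)C(F)(F)F)c1`, is the next member to be measured. It keeps every atom of compound 2 and rearranges one group: 3-methoxyphenyl in place of 2-methoxyphenyl on an amide-type nitrogen

Among the measured compounds shown here, no measured pair shows this change in isolation, so the size of the step in this assay cannot be read from data. The expectation is for a step no larger than the scatter, with no clear direction. Compound 3 is therefore expected near 8000 nM, within a range from 3000 nM to 22000 nM. The expected step of a 1.3-fold lower number from compound 2 to compound 3 (0.10 log units; within the scatter) is estimated to stay within the scatter.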

Compound 3, half-maximal inhibitory concentration: 6110 nM
Compound 3: the middle estimate sits 1.3-fold (0.12 log units) above what was measured; measured number inside the range.
By their numbers in this assay, from the lowest: compounds 1, 3 and 2 (each within the scatter of the next, the first and the last beyond it).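

Working notes on the aryl amide end. Among the compounds shown here, compound 2 and compound 3 give the first comparison that differs in one place only: in this assay, 3-methoxyphenyl in place of 2-methoxyphenyl on the amide-type nitrogen gives a 1.7-fold lower number from compound 2 to compound 3 (0.22 log units; within the scatter). With the same atoms joined differently, this read-out does not separate the two methoxyphenyl groups at this place, so the choice between them carries no measurable consequence here. Nothing measured on these compounds bears on the reason for the size of this step.

From the compounds shown here alone, whether this insensitivity holds for other groups stays open, for instance an amine or a hydroxyl group in place of the methoxy group, or a longer chain in place of the shared linker. For the compounds shown here, compound 1 differs from compound 2 and compound 3 in more than one place, so no step to it can be read, and what its aryl amide portion contributes in this assay remains unresolved.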